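The source may hold more compounds than are shown below. What is called first, only, known or untested is meant among the compounds shown, and "the series" means these compounds.

Compound 2 `CCCS(=O)(=O)Nc1ccc(F)c(C(=O)c2n[nH]c3ncc(-c4ccc(NS(C)(=O)=O)cc4)cc23)c1F` gives 0.85% in an assay for binding affinity to dual specificity mitogen-activated protein kinase kinase 4 (Homo sapiens), read by KINOMEscan, tested at 100 nM (on this read-out lower numbers stand for a stronger effect and higher numbers for a weaker effect at the one concentration tested), the lowest of the two numbers in hand; compound 1 `CCCS(=O)(=O)Nc1ccc(F)c(C(=O)c2n[nH]c3ncc(-c4ccccc4N)cc23)c1F` gives 23% in this assay. Among the compounds with values here, the one measured step, a number 22.2 percentage points lower from compound 1 to compound 2 (beyond the scatter), bears only loosely on compound 3 `CCCS(=O)(=O)Nc1ccc(F)c(C(=O)c2n[nH]c3ncc(-c4ccc(S(N)(=O)=O)cc4C)cc23)c1F`, since there the aryl group is rearranged rather than replaced: 2-methyl-4-sulfamoylphenyl in place of 4-(methanesulfonamido)phenyl on an aromatic carbon. Both groups keep a sulfonyl and a nitrogen on the ring, so the step from compound 2 to compound 3 is expected to be small, a number 2.2 percentage points higher from compound 2 to compound 3 (within the scatter), within or barely beyond the scatter. For compound 3 the expected value is 3%, in the range 0.5% to 15%.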

Compound 3, a percentage reported as activity, at one concentration (the size of the read-out at that concentration, not a potency): 3.1%
Compound 3: middle estimate off by 0.1 percentage points, on the low side; the range from low to high includes it.
By their numbers in this assay, from the lowest: compounds 2 and 3 (each within the scatter of the next); then compound 1.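

In this assay the low number at this position is not tied to 4-(methanesulfonamido)phenyl: 2-methyl-4-sulfamoylphenyl reads the same within the scatter (a number 2.3 percentage points higher from compound 2 to compound 3 (within the scatter)). The separation from 2-aminophenyl also holds for this second sulfonyl-bearing aryl group (a number 19.9 percentage points lower from compound 1 to compound 3 (beyond the scatter)). Nothing in hand explains either step.

From the compounds shown here alone, the methyl and sulfamoyl groups change together here, so what each contributes alone stays open. Also open, going by these compounds, is whether a carboxylic acid in place of the sulfamoyl group would keep the low number.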